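Swapping a furan for a thiazole in a cytotoxicity test

A few compounds are considered here, and "the series" means these few. Any claim that something is new, unique, unknown or untested is made for them only; others in the source may bear on it.

Measured compounds:
compound 1 `O=c1[nH]c(=O)n(C2C=CC(O)C2)cc1-c1cccs1` — >= 4000 nM
compound 2 `O=c1[nH]c(=O)n(C2C=CC(O)C2)cc1-c1ccco1` — > 100000 nM

In an ADME assay on HEL cells (Homo sapiens) for cytotoxicity, read by microscopy (a higher number here means that more compound is tolerated, a lower number that less compound is tolerated), compound 1 gives >= 4000 nM, which is a limit of the assay rather than a number. Compound 2 gives > 100000 nM, again a limit of the assay. The step that the two limits leave unreadable from compound 1 to compound 2 therefore cannot be sized, since both the limit of > 100000 nM in this assay, at which 1 of the 2 values shown sits, and the limit of >= 4000 nM in this assay, at which 1 of the 2 values shown sits, are limits. For the measured compounds named here, compound 2 thus stands at a limit of the assay, and the one other value shown is a limit too.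

Compound 3 `O=c1[nH]c(=O)n(C2C=CC(O)C2)cc1-c1cncs1` differs from compound 2 by 1,3-thiazol-5-yl in place of furan-2-yl on an aromatic carbon. Going by the values given here, no measured step covers this exchange, and the only measured step, from thiophen-2-yl to furan-2-yl, is unreadable. Nothing in the data points toward more or less tolerated compound, so compound 3 is expected to sit at a similar level, and the estimated step of an at least 2.0-fold lower number from compound 2 to compound 3 (0.30 log units; that floor lies within the scatter) is taken as none beyond the scatter. Compound 3 is expected to give about 50000 nM, with a range from 4000 nM to 100000 nM, most likely again reported only as a limit.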

Compound 3, minimum cytotoxic concentration: >= 100000 nM
Compound 3: only a limit was reported; the forecaster's own chance of this, stated with the estimate: 70%; at least 2.0-fold (0.30 log units) between middle value and limit.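

Compound 3 is reported only as a limit of the assay, as are compound 1 and compound 2, so no step among these three compounds can be read. The compounds shown leave open how much of each is actually tolerated in this assay, and whether the thiophen-2-yl, furan-2-yl and 1,3-thiazol-5-yl compounds differ at all.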